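The source may report more compounds than this note shows. Statements on the series, on what has been measured and on what is new or still open speak of the compounds shown alone.

Working notes. Compound 2 `CC(=O)OC[C@H]1O[C@@H](OCc2noc(-c3ccc([N+](=O)[O-])cc3)n2)[C@@H]2OC3(CCCC3)O[C@@H]21` carries the highest number of the two measured in a functional assay on SW1573 cells (Homo sapiens) for antiproliferative activity, read by sulforhodamine B assay, with a stated time of 48 h (a higher number here means a weaker inhibitor of growth, a lower number a stronger inhibitor of growth), at 29000 nM; its nearest neighbour, compound 1 `Nc1nnc(SC[C@H]2O[C@@H](OCc3noc(-c4ccc([N+](=O)[O-])cc4)n3)[C@@H]3OC4(CCCC4)O[C@@H]32)s1`, gives 16000 nM in this assay, and the step of a 1.8-fold higher number from compound 1 to compound 2 (0.26 log units; within the scatter) is within the scatter. Compound 3 `Cc1ccc(S(=O)(=O)OC[C@H]2O[C@@H](OCc3noc(-c4ccc([N+](=O)[O-])cc4)n3)[C@@H]3OC4(CCCC4)O[C@@H]32)cc1` differs from compound 2 by (4-methylphenyl)sulfonyl in place of acetyl on an oxygen on a saturated carbon, that is acetoxy to ((4-methylphenyl)sulfonyl)oxy on the saturated chain carbon. Among the measured compounds shown here, the only measured step in the set, from compound 1 to compound 2, exchanged the whole group on that chain carbon and moved the number by a 1.8-fold higher number from compound 1 to compound 2 (0.26 log units; within the scatter), within the scatter. The shared core is unchanged. For the measured compounds named here, no step bears directly on an acetyl to (4-methylphenyl)sulfonyl exchange, so no direction beyond the scatter is expected in this assay. Compound 3 is therefore estimated at 25000 nM, range 8000 nM to 80000 nM. The step implied for compound 3, a 1.2-fold lower number from compound 2 to compound 3 (0.06 log units; within the scatter), is expected to stay within the scatter.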

Compound 3, concentration for 50% growth inhibition: > 100000 nM
Compound 3: a limit, no number; the forecaster's own chance of this, stated with the estimate: 15%; middle value at least 4.0-fold (0.60 log units) away from the limit.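

For compound 3 the reading in this assay is a limit and not a number: the limit of > 100000 nM in this assay, at which 1 of the 3 values shown sits. The exchange of acetyl for (4-methylphenyl)sulfonyl on an oxygen on a saturated carbon gives an at least 3.4-fold higher number from compound 2 to compound 3 (0.53 log units; beyond the scatter), so the group on this chain carbon can move the number beyond the scatter, which a 1.8-fold higher number from compound 1 to compound 2 (0.26 log units; within the scatter) did not show. Exchange of (5-amino-1,3,4-thiadiazol-2-yl)sulfanyl for ((4-methylphenyl)sulfonyl)oxy on the same chain carbon points the same way, with an at least 6.2-fold higher number from compound 1 to compound 3 (0.79 log units; beyond the scatter), and both new steps give only a lower bound on their size.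

The compounds shown leave open whether the sulfonyl or the 4-methylphenyl ring goes with the weaker growth inhibition. A methanesulfonyl or a benzoyl group on the same oxygen would separate the two.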